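A cyclopropyl amide in place of a fluorophenyl urea

A few compounds are considered here, and "the series" means these few. Any claim that something is new, unique, unknown or untested is made for them only; others in the source may bear on it.

Compound 1 `CN1CCC(C(=O)N2Cc3c(NC(=O)Nc4cccc(F)c4)n[nH]c3C2(C)C)CC1` is measured in a physicochemical assay for solubility, at pH 7 (on this read-out lower numbers stand for lower solubility and higher numbers for higher solubility), where compound 1 reaches only the limit > 225000 nM and no number. Compound 2 `CN1CCC(C(=O)Nc2n[nH]c3c2CN(C(=O)C(C)(C)C)C3(C)C)CC1` likewise stops at the limit > 225000 nM. The ceiling of these two results is the limit of > 225000 nM in this assay, at which 2 of the 3 values shown sit. Compound 3 `CC(C)(C)C(=O)N1Cc2c(NC(=O)c3cccnc3)n[nH]c2C1(C)C` gives 207000 nM, and the step of an at least 1.0-fold lower number from compound 2 to compound 3 (0.03 log units; that floor lies within the scatter) lies within the scatter. Compound 4 `CN1CCC(C(=O)N2Cc3c(NC(=O)C4CC4)n[nH]c3C2(C)C)CC1` differs from compound 1 by cyclopropyl in place of (3-fluorophenyl)amino on a carbonyl carbon. Within the data shown here, no measured step carries this particular change, so the expectation rests on the high solubility that all three measured compounds share. The step of a number no higher from compound 1 to compound 4 (the limit leaves the size open) is expected to stay within the scatter. Compound 4 is therefore estimated at 225000 nM, in the range 90000 nM to 500000 nM.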

Compound 4, solubility: > 225000 nM
Compound 4: a limit, no number (the forecaster's own chance of this, stated with the estimate: 65%); the middle value sits exactly at the limit.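

Among these compounds, compound 1 and compound 4 both stop at a limit in this assay, so no step between them can be read: the limit of > 225000 nM in this assay, at which 3 of the 4 values shown sit. The compounds shown leave open whether cyclopropyl in place of (3-fluorophenyl)amino on a carbonyl carbon shifts this read-out at all.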